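The source may hold more compounds than are shown below. What is called first, only, known or untested is meant among the compounds shown, and "the series" means these compounds.

Measured in a functional assay on HUVEC cells (Homo sapiens), read by scintillation counting and thymidine incorporation, with a stated time of 24 h; a lower number here means a stronger inhibitor, a higher number a weaker inhibitor:
- compound 1 `CCC(C)n1ncn(-c2ccc(N3CCN(c4ccc(OC[C@@H]5CO[C@@](CC6CCCC6)(c6ccc(Cl)cc6Cl)O5)cc4)CC3)cc2)c1=O` gives 512 nM
- compound 2 `CCC(C)n1ncn(-c2ccc(N3CCN(c4ccc(OC[C@@H]5CO[C@@](Cn6ccnc6C)(c6ccc(Cl)cc6Cl)O5)cc4)CC3)cc2)c1=O` gives 173 nM
- compound 3 `CCC(C)n1ncn(-c2ccc(N3CCN(c4ccc(OC[C@@H]5CO[C@@](Cn6cc(C)nc6C)(c6ccc(Cl)cc6Cl)O5)cc4)CC3)cc2)c1=O` gives 492 nM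

Compound 3 stands in the upper pair of these three numbers, level with its nearest neighbour (a 1.0-fold lower number from compound 1 to compound 3 (0.02 log units; within the scatter)) and clear of the furthest (a 2.8-fold higher number from compound 2 to compound 3 (0.45 log units; beyond the scatter)).

Compound 4 `CCC(C)n1ncn(-c2ccc(N3CCN(c4ccc(OC[C@@H]5CO[C@@](Cn6cnnn6)(c6ccc(Cl)cc6Cl)O5)cc4)CC3)cc2)c1=O` keeps the shared core and changes one group: 1H-tetrazol-1-yl in place of 2,4-dimethyl-1H-imidazol-1-yl on a saturated chain carbon bound to a saturated ring carbon.

Two measured swaps at this same carbon gave a 3.0-fold lower number from compound 1 to compound 2 (0.47 log units; beyond the scatter) and a 1.0-fold lower number from compound 1 to compound 3 (0.02 log units; within the scatter), and one added methyl on an aromatic carbon gave a 2.8-fold higher number from compound 2 to compound 3 (0.45 log units; beyond the scatter). From the compounds shown here alone, all of these steps are small, but no tetrazole has been measured, so the direction remains open. No step beyond the scatter is expected in this assay, although a modest one either way would be no surprise. The expected step is a 1.2-fold lower number from compound 3 to compound 4 (0.09 log units; within the scatter) in this estimate. For compound 4 the estimated value is 400 nM, with an expected range from 130 nM to 1200 nM as its spread.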

Compound 4, half-maximal inhibitory concentration: 73 nM
Compound 4: middle estimate off by 5.5-fold (0.74 log units), on the high side; the measured number lies below the stated range.
By their numbers in this assay, from the lowest: compound 4; then compound 2; then compounds 3 and 1 (each within the scatter of the next).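

Placing 1H-tetrazol-1-yl on the saturated chain carbon bound to a saturated ring carbon gives the strongest inhibitor of the four in this assay (a 6.7-fold lower number from compound 3 to compound 4 (0.83 log units; beyond the scatter); a 2.4-fold lower number from compound 2 to compound 4 (0.37 log units; beyond the scatter); a 7.0-fold lower number from compound 1 to compound 4 (0.85 log units; beyond the scatter)). The earlier compounds shown here showed only that 2-methyl-1H-imidazol-1-yl improved on cyclopentyl and that a further methyl on the imidazole cancelled this gain; this result shows that a smaller, nitrogen-richer aromatic ring can go further than either imidazole. No measurement available here explains this gain.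

The compounds shown leave open whether the lower number follows the extra ring nitrogens or the loss of the methyl groups, as both change together in this swap. A triazole ring, or an imidazole ring carrying no methyl, at this carbon would help to separate the two.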